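Amide aryl variation on a shared core

The compounds below may be only part of what the source reports. "The series", "measured", "known", "first", "only" and "open" are said of these compounds alone.

Measured compounds:
compound 1: `COc1cc(-c2cc(C(=O)O)c3ccccc3n2)ccc1OCC(=O)Nc1cccc(F)c1` — 1.6
compound 2: `COc1cc(-c2cc(C(=O)O)c3ccccc3n2)ccc1OCC(=O)Nc1cccc(Cl)c1` — 2.3

In a physicochemical assay for lipophilicity, using the shake flask method, in phosphate buffer, measured as octanol-water partition, at pH 7.4 (on this read-out lower numbers stand for lower lipophilicity and higher numbers for higher lipophilicity), compound 2 gives 2.3, the highest of the two numbers; its nearest neighbour is compound 1, which gives 1.6. Among the compounds with values here, the one step between them, a number 0.70 log units higher from compound 1 to compound 2 (beyond the scatter), lies beyond the scatter and is modest in size.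

Compound 3 `COc1cc(-c2cc(C(=O)O)c3ccccc3n2)ccc1OCC(=O)Nc1ccccc1C(F)(F)F` has not yet been measured in this assay. The change from compound 2 is 2-(trifluoromethyl)phenyl in place of 3-chlorophenyl on an amide-type nitrogen. Within the data shown here, the only measured step that bears on it is a number 0.70 log units higher from compound 1 to compound 2 (beyond the scatter), which also alters the substituent on the aryl group attached to the amide-type nitrogen; the present change, however, exchanges chlorine for a trifluoromethyl group and shifts it within the ring, and no measured pair in this set covers either of those moves. Among the measured compounds shown here, on the one step available, a small rise is expected for compound 3, a number 0.20 log units higher from compound 2 to compound 3 (within the scatter), with a real chance that the step falls within the scatter.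

For compound 3 the estimate in this assay is 2.5, expected to fall between 2 and 3.1.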

Compound 3, distribution coefficient: 1.3
Compound 3: middle estimate off by 1.20 log units, on the high side; measured number outside the range, below it.
By their numbers in this assay, from the lowest: compounds 3 and 1 (each within the scatter of the next); then compound 2.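

In this assay, 2-(trifluoromethyl)phenyl in place of 3-chlorophenyl on the amide-type nitrogen gives a number 1.00 log units lower from compound 2 to compound 3 (beyond the scatter), so the entering aryl group, with 10 heavy atoms against 7, does not bring a higher number on this core. Set against the 3-fluorophenyl member, the same group gives a number 0.30 log units lower from compound 1 to compound 3 (within the scatter), so the read-out does not follow the heavy-atom count of the aryl group across these three compounds, and compound 2 alone stands apart from the other two, with steps to both beyond the scatter. No supporting information on the compounds accounts for this result.

The step from 3-chlorophenyl to 2-(trifluoromethyl)phenyl exchanges the substituent and alters its place on the ring in a single move, and the compounds shown do not separate these two changes. Also open, as far as these compounds go, is how this assay would respond to a nitrile or an amine on the aryl group attached to the amide-type nitrogen, since all three compounds carry only halogen-bearing substituents there.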